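A few compounds are considered here, and "the series" means these few. Any claim that something is new, unique, unknown or untested is made for them only; others in the source may bear on it.

Measured in a functional assay on MCF7 cells (Homo sapiens) for inhibition, read by MTT assay, with a stated time of 72 h; on this read-out higher numbers stand for weaker inhibition and lower numbers for stronger inhibition:
compound 1, `CN(C(=O)NC(=O)c1ccc(F)c(F)c1)c1nc(C(F)(F)F)c(C(=O)N/N=C/c2ccccc2C(F)(F)F)s1`, 8.21 ug/mL
compound 2, `CN(C(=O)NC(=O)c1ccc(Cl)cc1Cl)c1nc(C(F)(F)F)c(C(=O)N/N=C/c2ccccc2C(F)(F)F)s1`, 9.12 ug/mL
compound 3, `CN(C(=O)NC(=O)c1c(F)cccc1F)c1nc(C(F)(F)F)c(C(=O)N/N=C/c2ccccc2C(F)(F)F)s1`, 20.4 ug/mL

Compound 3 gives the highest number of the three in this assay; the nearest of the others lies a 2.2-fold higher number from compound 2 to compound 3 (0.35 log units; beyond the scatter) and the furthest a 2.5-fold higher number from compound 1 to compound 3 (0.40 log units; beyond the scatter). The two lower numbers stand within the scatter of each other, a 1.1-fold higher number from compound 1 to compound 2 (0.05 log units; within the scatter).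

Compound 4, `CN(C(=O)NC(=O)c1cccc([N+](=O)[O-])c1)c1nc(C(F)(F)F)c(C(=O)N/N=C/c2ccccc2C(F)(F)F)s1`, is not yet measured in this assay. It differs from compound 3 in one place: 3-nitrophenyl in place of 2,6-difluorophenyl on a carbonyl carbon. For the measured compounds named here, no measured step exchanges the 2,6-difluorophenyl for the 3-nitrophenyl. Going by the values given here, the steps that bear on it are the three exchanges of the aryl group on the same carbonyl carbon, all modest, the largest being a 2.5-fold higher number from compound 1 to compound 3 (0.40 log units; beyond the scatter). Since compound 3 holds the highest number of the set, moving away from the 2,6-difluorophenyl to another substituted ring is expected to give a modest lower number, a 1.7-fold lower number from compound 3 to compound 4 (0.23 log units; within the scatter). Compound 4 is therefore estimated at 12 ug/mL, with a range from 5 ug/mL to 30 ug/mL.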

Compound 4, half-maximal inhibitory concentration: 4.73 ug/mL
The estimate for compound 4 lay 2.5-fold (0.40 log units) above the measured number, and the stated range ends above it.
By their numbers in this assay, from the lowest: compounds 4, 1 and 2 (each within the scatter of the next); then compound 3.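

In this assay, a ring carrying no halogen is accepted on this carbonyl carbon: the 3-nitrophenyl cannot be separated from the 3,4-difluorophenyl (a 1.7-fold lower number from compound 1 to compound 4 (0.24 log units; within the scatter)) or from the 2,4-dichlorophenyl (a 1.9-fold lower number from compound 2 to compound 4 (0.29 log units; within the scatter)). The 2,6-difluorophenyl now stands apart from three other substituted rings, one of them free of halogen (a 4.3-fold lower number from compound 3 to compound 4 (0.63 log units; beyond the scatter)), so the high number of compound 3 is not a general feature of changing this aryl group. Nothing measured here explains that separation.

On these data alone, whether an aminophenyl or carboxyphenyl ring on this carbonyl carbon would stay level with compound 4 remains open. As far as these compounds go, how a plain phenyl, a cyclohexyl ring or a longer alkyl chain in place of the aryl group would read is also open.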